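This account rests on a few compounds, and the source may have more. Where it says the series, first, only, none or still open, it means among the compounds named here.

Measured compounds:
Compound 1, `C=CC1=C(C(=O)Nc2ccccc2)C(c2ccc(F)cc2)OC1`, in a functional assay on SW480 cells (Homo sapiens) for cytotoxicity, read by MTT assay, with a stated time of 24 h (on this read-out lower numbers stand for stronger inhibition and higher numbers for weaker inhibition), gives > 100000 nM, which is a limit of the assay and not a number.
Compound 2, `C=CC1=C(C(=O)Nc2cccc(C)c2)C(c2ccc(F)cc2)OC1`, in this assay gives > 100000 nM, again a limit rather than a number.

Within the data shown here, compound 2 therefore stands at the edge of what this assay can report, and so does the one other compound measured: the limit of > 100000 nM in this assay, at which 2 of the 2 values shown sit. Among the measured compounds shown here, the single step between them, a step that the two limits leave unreadable from compound 1 to compound 2, cannot be sized, because both of its ends are limits.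

Compound 3, `C=CC1=C(C(=O)NCc2ccccc2)C(c2ccc(F)cc2)OC1`, differs from compound 2 in one place: benzyl in place of 3-methylphenyl on an amide-type nitrogen. For the measured compounds named here, no measured step bears directly on this change, and the one step that exists is unreadable, so the data give no grounds for expecting a readable change in this assay. The expectation is that compound 3 also remains at the limit, with an estimated step of a number no higher from compound 2 to compound 3 (the limit leaves the size open). The value of compound 3 is accordingly estimated at 100000 nM, within the range 30000 nM to 300000 nM.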

Compound 3, half-maximal inhibitory concentration: > 100000 nM
Compound 3: a limit, no number; the forecaster's own chance of this, stated with the estimate: 75%; the middle value sits exactly at the limit.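

In this assay compound 3 gives > 100000 nM, which is a limit and not a number. The steps among compound 1, compound 2 and compound 3 therefore cannot be read: the limit of > 100000 nM in this assay, at which 3 of the 3 values shown sit. The compounds shown leave open how far each lies beyond that limit, and whether phenyl, 3-methylphenyl or benzyl on the amide-type nitrogen makes any difference.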